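The compounds below may be only part of what the source reports. "The series", "measured", "known", "first", "only" and "open" are said of these compounds alone.

Compound 3 `O=C(/C=C/c1ccc(Br)cc1)NS(=O)(=O)c1ccccc1` gives 3.9 ug/mL in a functional assay on B16-F10 cells (Mus musculus) for antiproliferative activity, read by ELISA and MTT assay, with a stated time of 48 h (a higher number here means a weaker inhibitor, a lower number a stronger inhibitor), the highest of the three numbers in hand, although the gaps to its neighbours are within the scatter. Compound 2 `O=C(/C=C/c1ccc(Cl)cc1)NS(=O)(=O)c1ccccc1` gives 2.2 ug/mL and compound 1 `O=C(/C=C/c1ccc(F)cc1)NS(=O)(=O)c1ccccc1` gives 2.1 ug/mL; the steps among them read a 1.0-fold higher number from compound 1 to compound 2 (0.02 log units; within the scatter), a 1.9-fold higher number from compound 1 to compound 3 (0.27 log units; within the scatter) and a 1.8-fold higher number from compound 2 to compound 3 (0.25 log units; within the scatter), none beyond the scatter. Compound 4 `O=C(/C=C/c1ccc(Br)cc1)NS(=O)(=O)c1ccc(Br)cc1` differs from compound 3 by bromo in place of hydrogen on an aromatic carbon. For the measured compounds named here, the measured steps all swap one halogen for another on the same ring and leave the sulfonyl-bearing phenyl untouched, so none bears directly on adding bromo in place of hydrogen there; they show only that halogen changes have stayed within the scatter. No step beyond the scatter is therefore expected. Compound 4 is estimated at 4 ug/mL, range 2 ug/mL to 8 ug/mL, an expected step of a 1.0-fold higher number from compound 3 to compound 4 (0.01 log units; within the scatter).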

Compound 4, half-maximal inhibitory concentration: 5.1 ug/mL
Compound 4: middle estimate off by 1.3-fold (0.11 log units), on the low side, and the stated range covers the measured number.
By their numbers in this assay, from the lowest: compounds 1, 2, 3 and 4 (each within the scatter of the next, the first and the last beyond it).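

On the sulfonyl-bearing ring, the change from phenyl to 4-bromophenyl gives a 1.3-fold higher number from compound 3 to compound 4 (0.12 log units; within the scatter) in this assay. For the compounds shown here, this is the first reading at this position, which stays unchanged across compound 1, compound 2 and compound 3, and here bromo in place of hydrogen produces no step beyond the scatter. No supporting data bear on the reason for this result.

Open, on these data alone, is whether an amine, a carboxylic acid or a methoxy group at this position would also stay within the scatter. Also open, as far as these compounds go, is whether bromo here behaves alike with fluoro or chloro on the other ring.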